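Phenoxy Replaces Furan-2-yl on a Bile Acid Receptor Scaffold

The compounds below may be only part of what the source reports. "The series", "measured", "known", "first", "only" and "open" are said of these compounds alone.

Compound 2 `Cc1ccccc1-n1nc(C)c2c1NC(=O)[C@H](C)S[C@@H]2c1ccc(-c2ccco2)cc1` gives 3600 nM in an assay on isolated protein for agonist activity at Bile acid receptor (Homo sapiens), read by AlphaScreen, with a stated time of 30 min (on this read-out lower numbers stand for an effect already at smaller amounts and higher numbers for an effect only at larger amounts of compound), and its nearest neighbour among the measured compounds is compound 1 `COc1cccc(-c2ccc([C@H]3S[C@@H](C)C(=O)Nc4c3c(C)nn4-c3ccccc3C)cc2)c1`, which gives 1800 nM; the step of a 2.0-fold higher number from compound 1 to compound 2 (0.30 log units; within the scatter) lies within the scatter. Compound 3 `Cc1ccccc1-n1nc(C)c2c1NC(=O)[C@H](C)S[C@@H]2c1ccc(Oc2ccccc2)cc1` differs from compound 2 by phenoxy in place of furan-2-yl on an aromatic carbon. Going by the values given here, the only measured step that bears on this change, from compound 1 to compound 2, was small, so no step beyond the scatter is expected in this assay, with a slightly lower number the more likely direction. Compound 3 is therefore expected to give 2500 nM, between 800 nM and 8000 nM, a step of a 1.4-fold lower number from compound 2 to compound 3 (0.16 log units; within the scatter).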

Compound 3, half-maximal effective concentration: 1300 nM
For compound 3 the middle estimate is 1.9-fold (0.28 log units) above the measured one; the range from low to high includes it.
By their numbers in this assay, from the lowest: compounds 3, 1 and 2 (each within the scatter of the next, the first and the last beyond it).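

In this assay, going by these compounds alone, the change from furan-2-yl to phenoxy, on an aromatic carbon para to a large group, gives a 2.8-fold lower number from compound 2 to compound 3 (0.44 log units; beyond the scatter) and is the first step at this position to pass beyond the scatter. Replacing 3-methoxyphenyl with phenoxy gives only a 1.4-fold lower number from compound 1 to compound 3 (0.14 log units; within the scatter), so these two groups cannot be told apart in this assay. Nothing available explains the step from furan-2-yl to phenoxy. The compounds shown leave open how an amine or a carboxylic acid at this place would read.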